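Removing the tert-butyl group from compound 2

A few compounds are considered here, and "the series" means these few. Any claim that something is new, unique, unknown or untested is made for them only; others in the source may bear on it.

- compound 1 `CCOC(=O)C1=C(N)Oc2ccccc2C1C(C#N)C(=O)OCC` gives 66000 nM
- compound 2 `CCOC(=O)C1=C(N)Oc2ccc(-c3ccc(C(C)(C)C)cc3)cc2C1C(C#N)C(=O)OCC` gives 800 nM
- compound 3 `CCCc1ccc2c(c1)C(C(C#N)C(=O)OCC)C(C(=O)OCC)=C(N)O2` gives 5200 nM

All three numbers come from a functional assay on Jurkat cells (Homo sapiens) for inhibition (on this read-out lower numbers stand for stronger inhibition of growth and higher numbers for weaker inhibition of growth), and compound 2 stands lowest among them. The closest gap to it is a 6.5-fold higher number from compound 2 to compound 3 (0.81 log units; beyond the scatter) and even that gap lies beyond the scatter.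

Compound 4 `CCOC(=O)C1=C(N)Oc2ccc(-c3ccccc3)cc2C1C(C#N)C(=O)OCC` differs from compound 2 in one place hydrogen in place of tert-butyl on an aromatic carbon and in words this is hydrogen in place of tert-butyl on an aromatic carbon, so that 4-(tert-butyl)phenyl becomes phenyl.

For the measured compounds named here, no measured step makes exactly this change, so the evidence is indirect. Putting 4-(tert-butyl)phenyl in place of hydrogen gave an 83-fold lower number from compound 1 to compound 2 (1.92 log units; beyond the scatter) and that step was large. Putting propyl in place of hydrogen gave a 13-fold lower number from compound 1 to compound 3 (1.10 log units; beyond the scatter) and that step was large too. Compound 4 keeps the phenyl, so it is expected to give back part of the drop in an 83-fold lower number from compound 1 to compound 2 (1.92 log units; beyond the scatter) but not all of it.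

The expected step is a 2.5-fold higher number from compound 2 to compound 4 (0.40 log units; beyond the scatter) in this assay and it would mean weaker inhibition of growth. For compound 4 the estimated value is 2000 nM with an expected range from 700 nM to 6000 nM in this assay.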

Compound 4, concentration for 50% growth inhibition: 3900 nM
The estimate for compound 4 lay 2.0-fold (0.29 log units) below the measured number; measured number inside the range.
By their numbers in this assay, from the lowest: compound 2; then compounds 4 and 3 (each within the scatter of the next); then compound 1.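

The tert-butyl group is not a passive passenger on the phenyl ring. In this assay, taking it off leaves a clear loss (a 4.9-fold higher number from compound 2 to compound 4 (0.69 log units; beyond the scatter)), so the low number of compound 2 depends on the whole 4-(tert-butyl)phenyl group and not on the phenyl ring alone. The plain phenyl still does a good deal by itself (a 17-fold lower number from compound 1 to compound 4 (1.23 log units; beyond the scatter)), which means that the step seen earlier for the full group is made up of a larger part reached with phenyl and a further part that needs the tert-butyl group. Phenyl and propyl, meanwhile, cannot be told apart at this position (a 1.3-fold lower number from compound 3 to compound 4 (0.12 log units; within the scatter)), so a ring is not shown to do better here than this short chain. Nothing among the data offers an explanation for the contribution of the tert-butyl group.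

As far as these compounds go, what a methyl, an amine or a carboxylic acid would do in place of the tert-butyl group stays open. So does whether a chain longer than propyl would reach the level of compound 2.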